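The source may hold more compounds than are shown below. What is called first, only, known or untested is meant among the compounds shown, and "the series" means these compounds.

Measured in a functional assay on HT-29 cells (Homo sapiens) for antiproliferative activity, read by MTT assay, with a stated time of 72 h; on this read-out lower numbers stand for stronger inhibition and higher numbers for weaker inhibition:
- Compound 1 `COC(=O)/C=C/CNc1ccc(Cl)c(S(=O)(=O)N(C)C)c1`: > 30000 nM, a limit of the assay and not a number
- Compound 2 `C=CC(=O)Nc1nc(-c2ccccc2)cs1`: 6600 nM
- Compound 3 `C=CC(=O)Nc1nc(-c2ccccc2)c(C)s1`: 22000 nM

Compound 3 has the higher of the two actual numbers. The nearest value is a single step away, a 3.3-fold higher number from compound 2 to compound 3 (0.52 log units; beyond the scatter), which is modest but beyond the scatter. Among the compounds with values here, that step, methyl in place of hydrogen on an aromatic carbon, is the only measured change at this carbon.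

Next is compound 4 `C=CC(=O)Nc1nc(-c2ccccc2)c(C(=O)OCC)s1`, with ethoxycarbonyl in place of methyl on an aromatic carbon. The ethoxycarbonyl sits next to the ring sulfur, on the carbon that holds methyl in compound 3. Compound 1 has a different structure and offers no guide to this change. Within the data shown here, the one relevant step, a 3.3-fold higher number from compound 2 to compound 3 (0.52 log units; beyond the scatter), went towards weaker inhibition, but it involved a far smaller group, so it sets only a rough scale and does not fix a direction.

In this assay a small move is expected, and the estimated step is a 1.4-fold lower number from compound 3 to compound 4 (0.14 log units; within the scatter). The estimate for compound 4 is 16000 nM, with an expected range of 5000 nM to 45000 nM.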

Compound 4, half-maximal inhibitory concentration: 18000 nM
Beside the measured number, compound 4's estimate is 1.1-fold (0.05 log units) below it, and the stated range covers the measured number.
By their numbers in this assay, from the lowest: compound 2; then compounds 4 and 3 (each within the scatter of the next). At a limit, above all of these: compound 1.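

Exchanging methyl for the larger ethoxycarbonyl on the aromatic carbon next to the ring sulfur gives no readable change in this assay (a 1.2-fold lower number from compound 3 to compound 4 (0.09 log units; within the scatter)), so compound 3 and compound 4 cannot be told apart here. Measured against hydrogen at this carbon, ethoxycarbonyl moves the same way as methyl (a 2.7-fold higher number from compound 2 to compound 4 (0.44 log units; beyond the scatter)), and with (a 3.3-fold higher number from compound 2 to compound 3 (0.52 log units; beyond the scatter)) both steps lie beyond the scatter towards weaker inhibition, with no compound shown going against this. Nothing measured here accounts for this result.

Still open, as far as these compounds go, is whether any group at this carbon, such as an amine or a carboxylic acid, can bring the number under that of compound 2 (6600 nM). Also open, from the compounds shown here alone, is whether the same order holds when the phenyl group carries a substituent such as a methoxy group.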